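Methoxy on the benzamide of compound 3

A few compounds are considered here, and "the series" means these few. Any claim that something is new, unique, unknown or untested is made for them only; others in the source may bear on it.

Measured compounds:
- compound 1, `COc1ccc(-c2cccc(C(=O)N(C)C)c2)cc1S(=O)(=O)Nc1ccc2ccc(NC(=O)c3ccccc3)cc2c1`: "nd" (no result reported) in a functional assay on CHO cells for agonist activity at Orexin receptor type 2 (Homo sapiens); on this read-out higher numbers stand for larger maximal responses and lower numbers for smaller maximal responses
- compound 2, `COc1ccc(-c2cccc(C(=O)N(C)C)c2)cc1S(=O)(=O)Nc1ccc2ccc(N(C)C(=O)c3ccccc3)cc2c1`: "nd" (no result reported) in this assay
- compound 3, `COc1ccc(-c2cccc(C(=O)N(C)C)c2)cc1S(=O)(=O)Nc1ccc2cccc(NC(=O)c3ccccc3)c2c1`: 112%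

Among the compounds with values here, compound 3 is the only member of the series with a number; in this assay compound 3 gives 112%, a response above that of the reference. Within the data shown here, compound 1 carries "nd" (no result reported) and compound 2 carries "nd" (no result reported), so no step between measured compounds can be read.

Compound 4, `COc1cccc(C(=O)Nc2cccc3ccc(NS(=O)(=O)c4cc(-c5cccc(C(=O)N(C)C)c5)ccc4OC)cc23)c1`, is not yet measured. Its difference from compound 3 is methoxy in place of hydrogen on an aromatic carbon on the benzoyl part, turning benzamido into ((3-methoxyphenyl)carbonyl)amino. With a single measured point there is no pattern to lean on; the expectation rests on compound 3 alone, whose response of 112% already sits near the top of the scale.

The step from compound 3 to compound 4 is expected to be a number 7 percentage points lower from compound 3 to compound 4 (within the scatter), within the usual scatter, with no clear direction. Compound 4 is therefore estimated at 105%, with a range from 80% to 125%.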

Compound 4, largest response reached (Emax), in percent of the reference or control that the assay uses: 104%
Beside the measured number, compound 4's estimate is 1 percentage points above it; measured number inside the range.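

Within this assay, methoxy in place of hydrogen on the benzoyl ring gives a number 8 percentage points lower from compound 3 to compound 4 (within the scatter) and supplies the first readable step in the series. At this place, meta to a large group, phenyl can thus become 3-methoxyphenyl with no change in maximal response that stands clear of the scatter. Nothing available here bears on the reason for this result.

On these data alone, this single step covers one group at one place, so it remains open whether an amine, a carboxylic acid or a longer chain such as butoxy would be tolerated there as well. As far as these compounds go, the response of methoxy at other carbons of the benzoyl ring also remains open, and a maximal response says nothing about potency.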